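This account rests on a few compounds, and the source may have more. Where it says the series, first, only, none or still open, it means among the compounds named here.

The series shares the core of compound 1 `CCCCCNC(=O)/N=C(\N)NCCCc1sc(N)nc1C`, which in a functional assay on Right cardiac atrium for agonist activity at histamine H2 receptor (Cavia porcellus), with a stated time of 30 min, in the presence of a further agent that is not named here (on this read-out lower numbers stand for an effect already at smaller amounts and higher numbers for an effect only at larger amounts of compound), gives 5.75 nM. Compound 2 `Cc1nc(N)sc1CCCN/C(N)=N/C(=S)N[C@H](C)c1ccccc1` gives 89.1 nM in this assay, and compound 3 `Cc1nc(N)sc1CCCN/C(N)=N/C(=O)N[C@@H](C)c1ccccc1` gives 23.4 nM. Compound 3 thus stands second highest of the three numbers, separated from compound 1 by a 4.1-fold higher number from compound 1 to compound 3 (0.61 log units; beyond the scatter); compound 2 differs from compound 3 in more than one place, so its value is only noted alongside, not counted as a step.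

Compound 4 `Cc1nc(N)sc1CCCN/C(N)=N/C(=O)NC(C)c1cccs1` is not yet measured in this assay. Its change from compound 3 is 1-(thiophen-2-yl)ethyl in place of 1-phenylethyl on an amide-type nitrogen. For the measured compounds named here, no measured step bears directly on this change: the one step in hand, a 4.1-fold higher number from compound 1 to compound 3 (0.61 log units; beyond the scatter), concerns the replacement of pentyl by 1-phenylethyl, not an exchange of one aromatic ring for another. With nothing in the data pointing either way, a step from compound 3 to compound 4 of no more than the usual scatter is expected, a 1.2-fold lower number from compound 3 to compound 4 (0.07 log units; within the scatter). Compound 4 is therefore expected to give about 20 nM in this assay, within roughly 8 nM to 50 nM.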

Compound 4, half-maximal effective concentration: 10 nM
Compound 4: middle estimate off by 2.0-fold (0.30 log units), on the high side, within the range that was stated.
By their numbers in this assay, from the lowest: compounds 1 and 4 (each within the scatter of the next); then compound 3; then compound 2.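

In this assay, the amide-type nitrogen responds to an exchange of one aromatic ring for another: 1-(thiophen-2-yl)ethyl in place of 1-phenylethyl gives a 2.3-fold lower number from compound 3 to compound 4 (0.37 log units; beyond the scatter), a modest step. An aromatic ring at this position is also not necessarily a loss against pentyl, since a 1.7-fold higher number from compound 1 to compound 4 (0.24 log units; within the scatter) stays within the scatter, whereas a 4.1-fold higher number from compound 1 to compound 3 (0.61 log units; beyond the scatter) lies beyond it. No evidence in hand accounts for the difference between the two rings.

Going by these compounds, the 1-(thiophen-2-yl)ethyl group carries no defined stereocentre, unlike the 1-phenylethyl group it replaces, so the contribution of each separate mirror-image form remains open. Also open, on these data alone, is whether the step extends to other rings or linkers, such as 1-(furan-2-yl)ethyl or a thiophen-2-ylmethyl group lacking the branching methyl.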